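A cyclohexyl ring in place of an ether chain

The source may report more compounds than this note shows. Statements on the series, on what has been measured and on what is new or still open speak of the compounds shown alone.

Compound 1, `COCCNC(=O)c1n[nH]cc1NC(=O)c1c(OC)cccc1OC`: in an ADME assay on MRC5 cells (Homo sapiens) for inhibition, with a stated time of 72 h (on this read-out lower numbers stand for an effect already at smaller amounts and higher numbers for an effect only at larger amounts of compound), compound 1 gives > 50000 nM, which is a limit of the assay and not a number.
Compound 2, `COc1cccc(OC)c1C(=O)Nc1c[nH]nc1C(=O)NCCCOC(C)C`: compound 2 gives > 50000 nM, again a limit of the assay.
Compound 3, `COc1cccc(OC)c1C(=O)Nc1c[nH]nc1C(=O)NC1CCN(Cc2ccccc2)C1`: compound 3 gives 38000 nM.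

Compound 2 therefore stands at the upper edge of what this assay can report, and it shares that position with compound 1, as the limit of > 50000 nM in this assay, at which 2 of the 3 values shown sit, records. Among the measured compounds shown here, the single step between neighbouring measured compounds, a step that the two limits leave unreadable from compound 1 to compound 2, runs from one limit to another and cannot be read for size or direction.

Compound 4, `COc1cccc(OC)c1C(=O)Nc1c[nH]nc1C(=O)NCC1CCCCC1`, is not yet measured. It differs from compound 2 in one place: cyclohexyl in place of 2-isopropoxyethyl on a saturated chain carbon bound to an amide-type nitrogen. For the measured compounds named here, no measured step in this set bears directly on that exchange; the one step that does exist is unreadable, and compound 3 carries a different substituent, so its value and that of compound 2 can only be set side by side, a number against a limit.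

With nothing pointing either way, compound 4 is expected to sit close to compound 2, the estimated step being an at least 1.1-fold lower number from compound 2 to compound 4 (0.04 log units; that floor lies within the scatter). Compound 4 is thus estimated at 45000 nM, with a range from 18000 nM to 110000 nM.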

Compound 4, half-maximal effective concentration: > 50000 nM
Compound 4: only a limit was reported; the forecaster's own chance of this, stated with the estimate: 55%; at least 1.1-fold (0.04 log units) between middle value and limit.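

In this assay compound 4 gives > 50000 nM, which is a limit of the assay and not a number. Compound 1, compound 2 and compound 4 all sit at limits, so no new step can be read among them: the limit of > 50000 nM in this assay, at which 3 of the 4 values shown sit. The compounds shown leave open whether cyclohexyl in place of 2-isopropoxyethyl changes this read-out at all.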